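An Added Chloro on the Anilide of Compound 1

This account rests on a few compounds, and the source may have more. Where it says the series, first, only, none or still open, it means among the compounds named here.

Among the compounds with values here, compound 1 `Cn1c(Cc2nn(C)c(=O)c3ccccc23)nnc1SCCCCCCCCCCC(=O)Nc1ccc(Cl)cc1` is the only compound with a numerical value here: in an assay on isolated protein (Mus musculus) for inhibition of IL15-IL15 receptor (Homo sapiens), read by resazurin assay, with stated times of 30 min and 2.5 days (on this read-out higher numbers stand for weaker inhibition and lower numbers for stronger inhibition), compound 1 gives 20000 nM. Compound 2 `Cn1c(Cc2nn(C)c(=O)c3ccccc23)nnc1SCC(=O)Nc1ccc(Br)cc1Br` reaches only a limit of the assay, > 30000 nM, in this assay. Compound 3 `Cn1c(Cc2nn(C)c(=O)c3ccccc23)nnc1SCCCCCCCCCCC(=O)Nc1ccc(Cl)cc1Cl` differs from compound 1 by chloro in place of hydrogen on an aromatic carbon, ortho to a large group and meta to a chloro group. Within the data shown here, with no measured step to lean on, the step from compound 1 to compound 3 is expected to stay within the usual scatter, no change at the digits printed from compound 1 to compound 3 (within the scatter). Compound 3 is therefore estimated at 20000 nM, between 8000 nM and 50000 nM.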

Compound 3, half-maximal inhibitory concentration: 3300 nM
For compound 3 the middle estimate is 6.1-fold (0.78 log units) above the measured one; measured number outside the range, below it.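

In this assay, within the data shown here, going from 4-chlorophenyl to 2,4-dichlorophenyl comes with a 6.1-fold lower number from compound 1 to compound 3 (0.78 log units; beyond the scatter), the only step that can be read here. This aromatic carbon, ortho to a large group and meta to a chloro group, therefore responds to substitution: a single chloro in place of hydrogen moves the number beyond the scatter. Compound 2 gives only a limit, so it adds no comparison: the limit of > 30000 nM in this assay, at which 1 of the 3 values shown sits.

On these data alone, whether fluoro, methyl or methoxy on this carbon would do the same stays open. So does how the 2,4-dichlorophenyl group behaves on a shorter chain.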